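Chloro for methoxy on the aryl ring of compound 2

This account rests on a few compounds, and the source may have more. Where it says the series, first, only, none or still open, it means among the compounds named here.

Measured so far:
- compound 1 `CC[C@@H](CCn1cncn1)c1ccc(Cl)cc1`: 55.3 ug/mL
- compound 2 `COc1ccc([C@H](CCn2cncn2)Cc2ccccc2)cc1`: 66 ug/mL

Going by the values given here, only two compounds carry a number in an ADME assay on RD cells (Homo sapiens) for cytotoxicity, read by MTT assay, with a stated time of 3 days; on this read-out lower numbers stand for higher toxicity in this test and higher numbers for lower toxicity in this test. Compound 2 gives 66 ug/mL in this assay and stands alongside compound 1, whose value of 55.3 ug/mL is not separated from it beyond the usual scatter; no ordering of the two can be read from these data.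

Compound 3 `Clc1ccc([C@H](CCn2cncn2)Cc2ccccc2)cc1` has not yet been tested in this assay. Against compound 2 the change is chloro in place of methoxy on an aromatic carbon: methoxy leaves, chloro enters, and the rest of the structure is kept. Among the compounds with values here, no pair of measured compounds isolates this exchange, so no measured step can be quoted for it. Compound 1 already carries the chloro group on a shortened frame and gives 55.3 ug/mL, a number within the scatter of compound 2.

The expectation for the step from compound 2 to compound 3 is therefore none beyond the scatter, a 1.1-fold lower number from compound 2 to compound 3 (0.06 log units; within the scatter). Compound 3 is estimated at 58 ug/mL in this assay, with a range from 35 ug/mL to 95 ug/mL.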

Compound 3, half-maximal cytotoxic concentration: 21.7 ug/mL
For compound 3 the middle estimate is 2.7-fold (0.43 log units) above the measured one; measured number outside the range, below it.
By their numbers in this assay, from the lowest: compound 3; then compounds 1 and 2 (each within the scatter of the next).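

In this assay, the aromatic carbon para to a large group proves responsive: chloro in place of methoxy gives a 3.0-fold lower number from compound 2 to compound 3 (0.48 log units; beyond the scatter) on the otherwise kept frame. The saturated chain carbon, two bonds along the chain from an aromatic carbon, also responds with chloro held fixed, as phenyl in place of methyl gives a 2.5-fold lower number from compound 1 to compound 3 (0.41 log units; beyond the scatter) and so also points to higher toxicity in this test. No measurement to hand accounts for either step.

As far as these compounds go, whether the lower number is specific to chloro or would also appear with fluoro, trifluoromethyl or a carboxylic acid at the same aromatic carbon remains open. Also open, from the compounds shown here alone, is whether the phenyl step would keep its size with methoxy on the aromatic ring, or with a longer chain in place of phenyl.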